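Aniline swap on a shared core: what compound 4 may give

A few compounds are considered here, and "the series" means these few. Any claim that something is new, unique, unknown or untested is made for them only; others in the source may bear on it.

Compound 1 `CCS(=O)(=O)Nc1cc(-c2ccc3ncnc(Nc4ccc(OC)c(Cl)c4)c3c2)cnc1OC` gives 5240 nM in a functional assay on A549 cells (Homo sapiens) for cytotoxicity, read by sulforhodamine B assay, with a stated time of 72 h; on this read-out lower numbers stand for stronger inhibition and higher numbers for weaker inhibition.
Compound 2 `CCS(=O)(=O)Nc1cc(-c2ccc3ncnc(Nc4ccc(F)c(C(=O)OC)c4)c3c2)cnc1OC` gives 3420 nM in this assay.
Compound 3 `CCS(=O)(=O)Nc1cc(-c2ccc3ncnc(Nc4ccc(Cl)c(C(=O)OC)c4)c3c2)cnc1OC` gives 2130 nM in this assay.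

Among the measured compounds shown here, compound 3 holds the lowest of the three numbers in this assay, but only the step of a 2.5-fold lower number from compound 1 to compound 3 (0.39 log units; beyond the scatter) lies beyond the scatter, while the step of a 1.6-fold lower number from compound 2 to compound 3 (0.21 log units; within the scatter) does not. Compound 4 `CCS(=O)(=O)Nc1cc(-c2ccc3ncnc(Nc4ccc(C(=O)OC)c(OC)c4)c3c2)cnc1OC` differs from compound 3 in that (3-methoxy-4-(methoxycarbonyl)phenyl in place of 4-chloro-3-(methoxycarbonyl)phenyl on a nitrogen on an aromatic ring). For the measured compounds named here, no measured step repeats this exchange; the nearest guides are a 2.5-fold lower number from compound 1 to compound 3 (0.39 log units; beyond the scatter), where a methoxy-bearing aniline gave the highest number, and a 1.6-fold lower number from compound 2 to compound 3 (0.21 log units; within the scatter), a small change between halogens. Compound 4 is therefore expected to return a somewhat higher number than compound 3, with a 1.7-fold higher number from compound 3 to compound 4 (0.23 log units; within the scatter) estimated, giving an estimate of 3600 nM within 1500 nM to 8500 nM in this assay.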

Compound 4, half-maximal inhibitory concentration: 3350 nM
Beside the measured number, compound 4's estimate is 1.1-fold (0.03 log units) above it; measured number inside the range.
By their numbers in this assay, from the lowest: compounds 3, 4, 2 and 1 (each within the scatter of the next, the first and the last beyond it).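

In this assay, 3-methoxy-4-(methoxycarbonyl)phenyl on the aromatic-ring nitrogen gives a 1.6-fold higher number from compound 3 to compound 4 (0.20 log units; within the scatter), a 1.0-fold lower number from compound 2 to compound 4 (0.01 log units; within the scatter) and a 1.6-fold lower number from compound 1 to compound 4 (0.19 log units; within the scatter), all three within the scatter. Among the compounds carrying methoxycarbonyl, the number therefore does not depend on a chloro or fluoro group being present, and compound 4 sits within the scatter of every earlier compound. From the compounds shown here alone, whether an amine or a carboxylic acid in place of methoxycarbonyl would give a number beyond that scatter remains open. No evidence is available that would explain these numbers.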